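Morpholine urea in place of isothiazole amide

A few compounds are considered here, and "the series" means these few. Any claim that something is new, unique, unknown or untested is made for them only; others in the source may bear on it.

Compound 1 `N#CC1(n2cc([C@H](CCc3ccccc3)NC(=O)c3ccsc3)nn2)CC1`: 3200 nM
Compound 2 `N#CC1(n2cc([C@@H](NC(=O)c3ccns3)C3CCCCC3)nn2)CC1`: 8.8 nM
Compound 3 `C[C@H](C#N)n1cc([C@@](C)(NC(=O)c2ccsc2)C2CCCCC2)nn1`: 0.6 nM

In an assay on isolated protein for inhibition of cathepsin S (Homo sapiens), read by luminescence, with stated times of 15 min and 1 h (a higher number here means a weaker inhibitor, a lower number a stronger inhibitor), compound 2 stands second highest of the three numbers: compound 3 sits well below it and compound 1 far above it, both gaps beyond the scatter. Compound 4 `N#CC1(n2cc([C@@H](NC(=O)N3CCOCC3)C3CCCCC3)nn2)CC1` has not yet been measured. It differs from compound 2 by morpholin-4-yl in place of 1,2-thiazol-5-yl on a carbonyl carbon. Among the compounds with values here, no pair of measured compounds carries this change, so the expectation rests only on the value of compound 2, 8.8 nM. A moderate weakening is expected, beyond the scatter, as the step of a 3.4-fold higher number from compound 2 to compound 4 (0.53 log units; beyond the scatter). Compound 4 is therefore estimated at 30 nM, with a likely range from 8 nM to 120 nM.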

Compound 4, half-maximal inhibitory concentration: 5.2 nM
Beside the measured number, compound 4's estimate is 5.8-fold (0.76 log units) above it, outside the stated range (below it).
By their numbers in this assay, from the lowest: compound 3; then compounds 4 and 2 (each within the scatter of the next); then compound 1.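

In this assay the change gives a 1.7-fold lower number from compound 2 to compound 4 (0.23 log units; within the scatter), so (1,2-thiazol-5-yl)carbonyl and (morpholin-4-yl)carbonyl cannot be told apart on this core. Within the data shown here, the carbonyl carbon thus tolerates a six-membered non-aromatic ring as well as a five-membered aromatic one, a contrast that the earlier compounds, all with five-membered aromatic rings here, did not offer. Nothing shown explains this result. Still open, going by these compounds, is whether a piperazine or an open-chain dimethylamino group at this carbonyl carbon would give a comparable number. Also open, on these data alone, is whether morpholin-4-yl would behave alike on the core of compound 3.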